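Sulfonamide swap from compound 2 to compound 3

The source may hold more compounds than are shown below. What is called first, only, known or untested is meant among the compounds shown, and "the series" means these compounds.

Half-lives in an ADME assay on microsomes from liver (Mus musculus, strain CD-1) for metabolic stability, read by LC-MS, tested at 2 uM; a lower number here means that the compound disappears faster, a higher number that the compound lasts longer
- Compound 1 `CN1CCC(CNS(=O)(=O)c2ccccc2Nc2cc(-c3ccc4ccn(C)c4c3)c3nccnc3c2)C1` gives 0.633 h
- Compound 2 `Cn1ccc2ccc(-c3cc(Nc4ccccc4S(=O)(=O)Nc4cncnc4)cc4nccnc34)cc21` gives 0.683 h

Compound 2 stands within the scatter of compound 1, so neither ranks over the other. Compound 3 `Cn1ccc2ccc(-c3cc(Nc4ccccc4S(=O)(=O)N4CCOCC4)cc4nccnc34)cc21` carries morpholin-4-yl in place of (pyrimidin-5-yl)amino on a sulfonyl sulfur. For the measured compounds named here, the one measured step, pyrimidin-5-yl in place of (1-methylpyrrolidin-3-yl)methyl on a sulfonamide nitrogen, is a 1.1-fold higher number from compound 1 to compound 2 (0.03 log units; within the scatter). Going by the values given here, no measured compound carries morpholin-4-yl, so the basis is thin, and no step beyond the scatter is expected. The expected change is a 1.1-fold lower number from compound 2 to compound 3 (0.04 log units; within the scatter). The estimated half-life of compound 3 is 0.62 h, with an expected range of 0.3 h to 1.3 h.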

Compound 3, half-life in the Mus musculus assay: 0.367 h
The estimate for compound 3 lay 1.7-fold (0.23 log units) above the measured number; measured number inside the range.
By their numbers in the Mus musculus assay, from the lowest: compounds 3, 1 and 2 (each within the scatter of the next).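

In the Mus musculus assay, a third group on the sulfonyl sulfur still gives no step beyond the scatter: a 1.9-fold lower number from compound 2 to compound 3 (0.27 log units; within the scatter), and a 1.7-fold lower number from compound 1 to compound 3 (0.24 log units; within the scatter). Among compounds 1, 2 and 3, this position therefore leaves half-life unresolved, while the same change from (pyrimidin-5-yl)amino to morpholin-4-yl separates compound 2 and compound 3 clearly in a physicochemical assay for solubility, read by spectrophotometry, measured as kinetic solubility, at pH 8, tested at 500 uM; a higher number here means a more soluble compound, a lower number a less soluble compound: the measured solubility of compound 2, 254 ug/mL, and of compound 3, 5 ug/mL, a 51-fold lower number (1.71 log units; beyond the scatter) In the physicochemical assay compound 2 gives 254 ug/mL and compound 3 gives 5 ug/mL.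

From the compounds shown here alone, whether piperazin-1-yl or dimethylamino on the sulfonyl sulfur would stay within the scatter in the Mus musculus assay remains open. So does where either group would fall in the physicochemical assay.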